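Aryl in place of carbamoylmethyl on the ring nitrogen

The source may hold more compounds than are shown below. What is called first, only, known or untested is meant among the compounds shown, and "the series" means these compounds.

Of the compounds shown here, three of the shared core have been tested in a functional assay on HeLa cells (Homo sapiens) for inhibition, read by MTT assay, with a stated time of 24 h; a lower number here means a stronger inhibitor, a higher number a weaker inhibitor. Compound 1 `O=C(O)C1=Cc2ccccc2OC1(OCc1cc(-c2ccc(F)cc2)no1)C(F)(F)F` reaches only the limit of the assay, > 150000 nM. Compound 2 `CCOC(=O)C1=Cc2ccccc2OC1(OCc1cn(CC(=O)Nc2cccc(F)c2)nn1)C(F)(F)F` likewise gives a limit rather than a number, > 150000 nM. Compound 3 `CCOC(=O)C1=Cc2ccccc2OC1(OCc1cc(-c2ccc3ccccc3c2)no1)C(F)(F)F` also stops at the limit, > 150000 nM. Compound 2 therefore stands where every value shown stands: the limit of > 150000 nM in this assay, at which 3 of the 3 values shown sit. Compound 4 `CCOC(=O)C1=Cc2ccccc2OC1(OCc1cn(-c2ccc(F)c(Cl)c2)nn1)C(F)(F)F` differs from compound 2 in one place: 3-chloro-4-fluorophenyl in place of ((3-fluorophenyl)carbamoyl)methyl on an aromatic nitrogen. Among the measured compounds shown here, no step between measured compounds is available, so the size of this change cannot be read from the series itself. With all three measured compounds at the limit, the step in this assay is estimated as none beyond the scatter: a number no higher from compound 2 to compound 4 (the limit leaves the size open). Compound 4 is expected at 150000 nM, with a range from 40000 nM to 500000 nM, most likely reported again as a limit.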

Compound 4, half-maximal inhibitory concentration: 22700 nM
Compound 4: middle estimate off by 6.6-fold (0.82 log units), on the high side; measured number outside the range, below it.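

In this assay, the aromatic nitrogen of the five-membered ring proves a position that can move the read-out: 3-chloro-4-fluorophenyl in place of ((3-fluorophenyl)carbamoyl)methyl gives an at least 6.6-fold lower number from compound 2 to compound 4 (0.82 log units; beyond the scatter). Among the compounds shown here, compound 4 is the only compound with a number rather than a limit: the limit of > 150000 nM in this assay, at which 3 of the 4 values shown sit. This single step changes the ring substituents and removes the carbamoylmethyl link together, so it cannot separate the two.

Going by these compounds, whether an unsubstituted phenyl or a benzyl on the same nitrogen would keep the step stays open. The separate roles of the chlorine and the fluorine also remain unresolved.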